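A few compounds are considered here, and "the series" means these few. Any claim that something is new, unique, unknown or untested is made for them only; others in the source may bear on it.

Measured so far:
compound 1, `ClCc1ccc(Cn2cnc3c(Cl)ncnc32)cc1` — 2450 nM in a functional assay on HCT-116 cells (Homo sapiens) for cytotoxicity, read by sulforhodamine B assay, with a stated time of 48 h; on this read-out higher numbers stand for weaker inhibition of growth and lower numbers for stronger inhibition of growth
compound 2, `ClCc1ccccc1Cn1cnc2c(Cl)nc(Cl)nc21` — 380 nM in this assay

Compound 2 has the lowest of the two numbers; the nearest is compound 1, which gives a number well beyond the scatter of repeated measurements, so compound 2 is the stronger inhibitor of growth among the two. Among the measured compounds shown here, the two compounds differ in more than one place, and no single step connects them; their values alone show the gap.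

Compound 3, `ClCc1ccccc1Cn1cnc2c(Cl)ncnc21`, is compound 2 with one change: hydrogen in place of chloro on an aromatic carbon. No measured step of this kind exists among these compounds, so the size of the effect cannot be read from a neighbour. A loss of a chloro group from the shared core is expected to weaken inhibition of growth in this assay by a moderate amount, though an outcome within the scatter cannot be excluded. The step from compound 2 to compound 3 is estimated as a 3.9-fold higher number from compound 2 to compound 3 (0.60 log units; beyond the scatter). Compound 3 is therefore expected to give about 1500 nM, with a range from 500 nM to 5000 nM.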

Compound 3, concentration for total growth inhibition: 3710 nM
Beside the measured number, compound 3's estimate is 2.5-fold (0.39 log units) below it; measured number inside the range.
By their numbers in this assay, from the lowest: compound 2; then compounds 1 and 3 (each within the scatter of the next).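

In this assay, hydrogen in place of chloro on the aromatic carbon between two ring nitrogen atoms gives a 9.8-fold higher number from compound 2 to compound 3 (0.99 log units; beyond the scatter), a step beyond the scatter. This is the first change among these compounds that can be read on its own, since compound 2 and compound 3 differ only in this one place. It shows that, within this pair, the chloro group at this position goes with the stronger inhibition of growth, with compound 2 at 380 nM. Nothing available here explains why this atom makes such a difference.

The compounds shown leave open whether another group at this position, such as an amine, a methoxy group or a fluoro group, would keep the number near that of compound 2 or move it towards that of compound 3. They also leave open whether adding the same chloro group to compound 1 would bring a step of similar size.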